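Swapping Trifluoromethyl for Cyano on Compound 1

This account rests on a few compounds, and the source may have more. Where it says the series, first, only, none or still open, it means among the compounds named here.

Measured compounds:
- compound 1, `CN(C)CCCOc1ccc(CN(C)c2nc3ccc(Oc4ccc(C(F)(F)F)cc4)cc3s2)cc1`: 46000 nM
- compound 2, `CN(Cc1ccc(OCCCNC(=N)N)cc1)c1nc2ccc(Oc3ccccc3)cc2s1`: 113000 nM
- compound 3, `CN(Cc1ccc(OCCCN)cc1)c1nc2ccc(Oc3ccccc3)cc2s1`: 49000 nM

These three compounds share one core and were tested in an assay on SH-SY5Y cells for inhibition of Voltage-dependent N-type calcium channel subunit alpha-1B (Homo sapiens), read by FLIPR and calcium flux, with stated times of 600 s and 300 s, in the presence of a further agent that is not named here; a lower number here means a stronger inhibitor, a higher number a weaker inhibitor. Compound 1 gives the lowest of the three numbers. Compound 3 sits within the scatter of compound 1, so the two cannot be told apart. For the measured compounds named here, compound 2 lies beyond the scatter above compound 1, and the only step that can be read directly, a 2.3-fold lower number from compound 2 to compound 3 (0.36 log units; beyond the scatter), is a modest one on an amine nitrogen at the far end of the molecule.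

Compound 4, `CN(C)CCCOc1ccc(CN(C)c2nc3ccc(Oc4ccc(C#N)cc4)cc3s2)cc1`, is not yet measured. It differs from compound 1 in one place: cyano in place of trifluoromethyl on an aromatic carbon. Going by the values given here, this change sits on an aromatic carbon of a six-membered aromatic ring of carbon only, a part of the molecule that none of the measured compounds varies. Among the compounds with values here, the one step on record, from compound 2 to compound 3, concerns a different region, so it offers no guide to the size or direction of this change.

Within the data shown here, with no bearing step to lean on, compound 4 is expected to land close to compound 1, at an estimated 46000 nM with a range from 15000 nM to 140000 nM; the expected step is no change at the digits printed from compound 1 to compound 4 (within the scatter), which is no step beyond the scatter.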

Compound 4, half-maximal inhibitory concentration: 69000 nM
Estimate against measurement, compound 4: 1.5-fold (0.18 log units) below; the measured number falls inside the stated range.
By their numbers in this assay, from the lowest: compounds 1, 3, 4 and 2 (each within the scatter of the next, the first and the last beyond it).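

In this assay, for the compounds shown here, this is the first direct reading of the aromatic ring that carries the trifluoromethyl group, as the one earlier step concerned an amine nitrogen at the far end of the molecule. Cyano in place of trifluoromethyl gives a 1.5-fold higher number from compound 1 to compound 4 (0.18 log units; within the scatter), so the two groups cannot be told apart at this position, even though the swap adds a hydrogen-bond acceptor. Nothing available here speaks to what lies behind this result.

From the compounds shown here alone, a single swap between two groups says little about the position as a whole, so it remains open whether a bare hydrogen, a chlorine atom, a methoxy group or a carboxylic acid at this same place would give a number beyond the scatter of compound 1. Going by these compounds, it is also open whether cyano in place of trifluoromethyl would read the same in a compound with a different far end, such as the guanidine of compound 2 or the unsubstituted amine of compound 3.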